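Catechol-bearing analog of a pyrazole-pyrimidinone nitrile series

The source may report more compounds than this note shows. Statements on the series, on what has been measured and on what is new or still open speak of the compounds shown alone.

Of the compounds shown here, two of a shared core have been measured in a functional assay, with a stated time of 150 min; on this read-out higher numbers stand for weaker inhibition and lower numbers for stronger inhibition. Compound 1, `CCOC(=O)c1cnn(-c2nc(-c3ccco3)c(C#N)c(=O)n2C)c1N`, gives 108 ug/mL. Going by the values given here, compound 2, `CCOC(=O)c1cnn(-c2nc(-c3cccs3)c(C#N)c(=O)n2C)c1N`, gives 98 ug/mL, which is the lowest of the two numbers; its only neighbour is compound 1, and the step of a 1.1-fold lower number from compound 1 to compound 2 (0.04 log units; within the scatter) lies within the scatter. Compound 3, `CCOC(=O)c1cnn(-c2nc(-c3cccc(O)c3O)c(C#N)c(=O)n2C)c1N`, is the next compound in the series. It differs from compound 2 in one place: 2,3-dihydroxyphenyl in place of thiophen-2-yl on an aromatic carbon. Among the compounds with values here, no measured step involves this entering group, and the single step available, from a furan to a thiophene, was too small to show whether a change at this position moves this assay at all. An outcome close to compound 2 is therefore expected, with a wide margin for a 1.3-fold lower number from compound 2 to compound 3 (0.12 log units; within the scatter). Compound 3 is estimated at 75 ug/mL, with a range from 25 ug/mL to 220 ug/mL.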

Compound 3, half-maximal inhibitory concentration: 58 ug/mL
For compound 3 the middle estimate is 1.3-fold (0.11 log units) above the measured one; the measured number falls inside the stated range.
By their numbers in this assay, from the lowest: compounds 3, 2 and 1 (each within the scatter of the next).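

In this assay, the aromatic carbon ortho to a cyano group now carries a much greater exchange than furan for thiophene: 2,3-dihydroxyphenyl in place of thiophen-2-yl gives a 1.7-fold lower number from compound 2 to compound 3 (0.23 log units; within the scatter) on this read-out, and 2,3-dihydroxyphenyl in place of furan-2-yl gives a 1.9-fold lower number from compound 1 to compound 3 (0.27 log units; within the scatter) on the same read-out. A six-membered aromatic ring of 8 heavy atoms with 2 hydrogen-bond donors, entering for a five-membered aromatic ring of 5 heavy atoms with 0 donors, thus leaves the number within the scatter, so none of the three groups stands apart at this position. No measurement is at hand that would explain these small steps.

From the compounds shown here alone, what an amine, a carboxylic acid or a longer alkyl chain on this carbon would do remains open. So does whether a plain phenyl would give a number like that of 2,3-dihydroxyphenyl.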